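Swapping the aryl group on the chain carbon of compound 2

A few compounds are considered here, and "the series" means these few. Any claim that something is new, unique, unknown or untested is made for them only; others in the source may bear on it.

Of the compounds shown here, two with a shared core have been measured so far in an ADME assay on microsomes from liver (Homo sapiens) for metabolic stability; a higher number here means that the compound lasts longer, a lower number that the compound disappears faster. Compound 1, `COc1nc2ccc(Br)cc2cc1[C@@H](c1ccnc(OC)c1OC)[C@@](O)(CCN(C)C)c1cccc(OC(F)F)c1`, gives 1.02 h in this assay. Compound 2, `COc1nc2ccc(Br)cc2cc1[C@@H](c1cccnc1N(C)C)[C@@](O)(CCN(C)C)c1cccc(F)c1`, gives 0.25 h in this assay, the lowest of the two numbers. Within the data shown here, the gap between compound 2 and compound 1 lies beyond the usual scatter, though no single-point step connects the two structures, since they differ in more than one place.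

The next compound, compound 3, `COc1nc2ccc(Br)cc2cc1[C@@H](c1cc(C)c(C)s1)[C@@](O)(CCN(C)C)c1cccc(F)c1`, is not yet measured. It differs from compound 2 in one place: 4,5-dimethylthiophen-2-yl in place of 2-(dimethylamino)pyridin-3-yl on a saturated chain carbon bound to an aromatic carbon and a saturated chain carbon. Among the measured compounds shown here, the two measured compounds offer no step that tells how an exchange of this kind acts on the half-life, so the direction is open. In the absence of such a guide, the step from compound 2 to compound 3 is expected to stay within the scatter, a 1.2-fold higher number from compound 2 to compound 3 (0.08 log units; within the scatter). Compound 3 is therefore estimated at 0.3 h in this assay, with a range from 0.1 h to 0.9 h.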

Compound 3, half-life: 1 h
The estimate for compound 3 lay 3.3-fold (0.52 log units) below the measured number; measured number outside the range, above it.
By their numbers in this assay, from the lowest: compound 2; then compounds 3 and 1 (each within the scatter of the next).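

Among these compounds, the exchange of 2-(dimethylamino)pyridin-3-yl for 4,5-dimethylthiophen-2-yl gives the first single-place reading in this assay for the shared core, with a 4.0-fold higher number from compound 2 to compound 3 (0.60 log units; beyond the scatter) as its result. It shows that the group on this saturated chain carbon, bound to an aromatic carbon and a saturated chain carbon, can by itself move the half-life beyond the scatter, something the earlier pair could not show since its members differ in more than one place. Nothing available bears on why the number moves.

Going by these compounds, it remains open whether the step reflects the departure of 2-(dimethylamino)pyridin-3-yl, the arrival of the thiophene ring or the methyl groups on that ring, and a single pair cannot separate these readings or show that the step carries over to other members. A plain phenyl ring, an unsubstituted thiophen-2-yl or a 2-methoxypyridin-3-yl group in this place would help to divide the step among these parts.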